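A nitrile traded for fluoro in a clearance series

The compounds below may be only part of what the source reports. "The series", "measured", "known", "first", "only" and "open" are said of these compounds alone.

Measured in an in vitro ADME assay on microsomes from liver (Homo sapiens) for metabolic stability; on this read-out higher numbers stand for fast clearance and lower numbers for slow clearance:
Compound 1 `CC(C)NC(=O)[C@H]1CC[C@@H](n2/c(=N/C(=O)c3ccc(C#N)c(F)c3)[nH]c3ccc(CN4CCC(C(C)(C)O)CC4)cc32)CC1`: 132 mL.min-1.g-1
Compound 2 `CC(C)NC(=O)[C@H]1CC[C@@H](n2/c(=N/C(=O)c3ccc(F)cc3)[nH]c3ccc(CN4CC(C(C)(C)O)C4)cc32)CC1`: 105 mL.min-1.g-1

In this assay compound 1 gives 132 mL.min-1.g-1 and compound 2 gives 105 mL.min-1.g-1, two numbers within the usual scatter of each other. For the measured compounds named here, compound 1 therefore stands level with the only other measured compound, and neither can be ranked above the other.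

The unmeasured compound 3 `CC(C)NC(=O)[C@H]1CC[C@@H](n2/c(=N/C(=O)c3ccc(F)c(F)c3)[nH]c3ccc(CN4CCC(C(C)(C)O)CC4)cc32)CC1` keeps the core of compound 1 and differs in one place: fluoro in place of cyano on an aromatic carbon. Fluoro takes the place of cyano on an aromatic carbon, ortho to a fluoro group and para to a large group, so that 4-cyano-3-fluorophenyl becomes 3,4-difluorophenyl. Going by the values given here, no measured pair here shows this exchange on its own, and the data offer no direct precedent for its size or direction. The expectation therefore starts from compound 1 at 132 mL.min-1.g-1 and assumes no step beyond the scatter in either direction. The estimated change, a 1.0-fold lower number from compound 1 to compound 3 (0.01 log units; within the scatter), is expected to be negligible. For compound 3 the estimated value is 130 mL.min-1.g-1, with an expected range from 75 mL.min-1.g-1 to 220 mL.min-1.g-1.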

Compound 3, intrinsic clearance in microsomes: 60 mL.min-1.g-1
Compound 3: middle estimate off by 2.2-fold (0.34 log units), on the high side, outside the stated range (below it).
By their numbers in this assay, from the lowest: compounds 3, 2 and 1 (each within the scatter of the next, the first and the last beyond it).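

In this assay, putting fluoro in place of cyano on an aromatic carbon, ortho to a fluoro group and para to a large group, gives a 2.2-fold lower number from compound 1 to compound 3 (0.34 log units; beyond the scatter), so the read-out responds to what sits at this position. For the compounds shown here, this is the first step that can be tied to one place, since 4-cyano-3-fluorophenyl becomes 3,4-difluorophenyl while the rest of compound 1 stays as it is, whereas the two earlier compounds differ in more than one place and could not isolate any single exchange. Nothing available here bears on why the number falls with this exchange.

The compounds shown leave open whether the step belongs to the arrival of fluoro or to the departure of the nitrile, a question that chloro, methoxy or a plain hydrogen on the same aromatic carbon would help to settle. They also leave open whether the exchange would give a step of similar size and direction with another group on the far side of the shared core, such as a morpholine in place of the substituted piperidine.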